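A pyridyl amide replaces a halogenated anilide on the core

The compounds below may be only part of what the source reports. "The series", "measured", "known", "first", "only" and "open" are said of these compounds alone.

Compound 1 `Cc1ccc(NC(=O)COc2ccc3cc(/C=C4/SC(=O)NC4=O)ccc3c2)cc1` gives 9000 nM in an assay on isolated protein for inhibition of histone deacetylase 8 (Homo sapiens), with a stated time of 1 h; a lower number here means a stronger inhibitor, a higher number a weaker inhibitor.
Compound 2 `O=C(COc1ccc2cc(/C=C3/SC(=O)NC3=O)ccc2c1)Nc1ccc(Br)cc1` gives 16000 nM in this assay.
Compound 3 `O=C(COc1ccc2cc(/C=C3/SC(=O)NC3=O)ccc2c1)Nc1cc(Cl)cc(C(F)(F)F)c1` gives > 50000 nM in this assay, and this is a limit of the assay rather than a number.

Compound 3 stands at the weak end of the measured set: it sits at the limit (the limit of > 50000 nM in this assay, at which 1 of the 3 values shown sits), and nothing more than that limit is known of it. The two steps that reach it, an at least 5.5-fold higher number from compound 1 to compound 3 (0.74 log units; beyond the scatter) and an at least 3.1-fold higher number from compound 2 to compound 3 (0.49 log units; beyond the scatter), both run beyond the scatter, whereas a 1.8-fold higher number from compound 1 to compound 2 (0.25 log units; within the scatter) stays within it. Compound 4 `Cc1cccc(NC(=O)COc2ccc3cc(/C=C4/SC(=O)NC4=O)ccc3c2)n1` differs from compound 3 in one place: 6-methylpyridin-2-yl in place of 3-chloro-5-(trifluoromethyl)phenyl on an amide-type nitrogen. Within the data shown here, no measured step exchanges an aryl group on the amide nitrogen for a pyridyl group, so the measured steps bear on this change only indirectly: they show that the 3-chloro-5-(trifluoromethyl)phenyl in compound 3 lies beyond the values of compounds 1 and 2, whose methyl- and bromo-bearing phenyl groups give numbers. Leaving that group is therefore expected to bring the number back toward the values of compounds 1 and 2. Compound 4 is expected at 15000 nM, within a range from 5000 nM to 50000 nM. The expected step is an at least 3.3-fold lower number from compound 3 to compound 4 (0.52 log units; beyond the scatter), downward, though compound 3 gives only a limit, so its true size is uncertain.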

Compound 4, half-maximal inhibitory concentration: 7500 nM
Estimate against measurement, compound 4: 2.0-fold (0.30 log units) above, and the stated range covers the measured number.
By their numbers in this assay, from the lowest: compounds 4, 1 and 2 (each within the scatter of the next, the first and the last beyond it). At a limit, above all of these: compound 3.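

Compound 3 remains a limit of the assay and not a number, so the step out of it has a lower bound only: the limit of > 50000 nM in this assay, at which 1 of the 4 values shown sits.

In this assay the change to 6-methylpyridin-2-yl on the amide-type nitrogen gives an at least 6.6-fold lower number from compound 3 to compound 4 (0.82 log units; beyond the scatter) and shows that a ring with a hetero atom still gives a measurable number at this position, something none of compounds 1 to 3 could show, as each carries a ring of carbon only. Set against the two phenyl groups that give numbers, the new ring behaves differently in each comparison: a 2.1-fold lower number from compound 2 to compound 4 (0.33 log units; beyond the scatter) is a modest step beyond the scatter, while a 1.2-fold lower number from compound 1 to compound 4 (0.08 log units; within the scatter) stays within it, so compound 4 cannot be told apart from the 4-methylphenyl compound.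

The compounds shown leave open whether the ring nitrogen or the methyl group of 6-methylpyridin-2-yl accounts for this result, a question that a plain pyridin-2-yl group or a pyrimidin-2-yl ring would help to separate. Also open, from the compounds shown here alone, is how a methoxy group or an amine in place of that methyl group would read in this assay on the same ring.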